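The source may hold more compounds than are shown below. What is called first, only, known or untested is meant among the compounds shown, and "the series" means these compounds.

Measured compounds:
Compound 1 `CC(C)C(NS(=O)(=O)Cc1ccccc1)C(=O)N1CCC(c2ccc(Cl)cc2)CC1` gives 303 nM in an assay on THP-1 cells for displacement of a labelled ligand from C-C chemokine receptor type 1 (Homo sapiens); a higher number here means a weaker inhibitor, a lower number a stronger inhibitor.
Compound 2 `CC(C)[C@@H](NC(=O)c1nc2ccccc2s1)C(=O)N1CCC(c2ccc(Cl)cc2)CC1` gives 18 nM in this assay.
Compound 3 `CCCC(NC(=O)c1ccccc1C)C(=O)N1CCC(c2ccc(Cl)cc2)CC1` gives 152 nM in this assay.

Of these three, compound 2 stands at the lowest number, and its gaps to compound 3 and to compound 1 both lie beyond the scatter, so it is the strongest inhibitor of the group. Compound 4 `CC(C)[C@@H](NC(=O)C1CCCC1)C(=O)N1CCC(c2ccc(Cl)cc2)CC1` has not been measured. It differs from compound 2 in one place: cyclopentyl in place of 1,3-benzothiazol-2-yl on a carbonyl carbon. For the measured compounds named here, no measured pair here shows this change, so the expected step rests on the wider spread: the two other amide-type compounds, compound 1 and compound 3, both sit well above compound 2. The step from compound 2 to compound 4 is expected to be upward and beyond the scatter, an 8.3-fold higher number from compound 2 to compound 4 (0.92 log units; beyond the scatter). Compound 4 is therefore estimated at 150 nM, within a range of 40 nM to 600 nM.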

Compound 4, half-maximal inhibitory concentration: 70 nM
Compound 4: the middle estimate sits 2.1-fold (0.33 log units) above what was measured; low and high end bracket the measured number.
By their numbers in this assay, from the lowest: compound 2; then compound 4; then compounds 3 and 1 (each within the scatter of the next).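

In this assay, for the compounds shown here, cyclopentyl in place of 1,3-benzothiazol-2-yl on a carbonyl carbon gives a 3.9-fold higher number from compound 2 to compound 4 (0.59 log units; beyond the scatter) and provides the first single-place step. The step lies beyond the scatter, so the group at this place affects the number, yet compound 4 shows that inhibition persists with neither an aromatic ring nor a hetero atom in that group. No evidence here explains the rise. From the compounds shown here alone, whether a thiazole ring or a pyridine ring at this place would fall nearer compound 2 or compound 4 remains open.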